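This account rests on a few compounds, and the source may have more. Where it says the series, first, only, none or still open, it means among the compounds named here.

Among the compounds with values here, compound 2 `CO[C@@H]1CC=C2NN(c3cccnc3)C(=O)C[C@]2(C)O1` gives the lowest of the two numbers so far: in a functional assay on HCT-116 cells (Homo sapiens) for inhibition, read by sulforhodamine B assay, with a stated time of 48 h (a lower number here means a stronger inhibitor, a higher number a weaker inhibitor), compound 2 gives 17100 nM, while compound 1 `CO[C@@H]1CC=C2NN(c3ccc(Cl)cc3)C(=O)C[C@]2(C)O1` gives 35700 nM. Within the data shown here, the only measured step, a 2.1-fold lower number from compound 1 to compound 2 (0.32 log units; beyond the scatter), is a modest one and sits just beyond the scatter.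

Compound 3 `CO[C@@H]1CC=C2NN(c3ccc(C)cc3)C(=O)C[C@]2(C)O1` differs from compound 2 by 4-methylphenyl in place of pyridin-3-yl on an amide-type nitrogen in a ring. This is close to a reversal of the measured step, since an aromatic ring of carbon only again replaces the pyridin-3-yl, now with a methyl group rather than a chlorine atom on it. The step from compound 1 to compound 2 is therefore the only one that bears on the change, and it points to a modest rise in the number, roughly of the size seen there, with the direction more secure than the magnitude. Compound 3 is thus expected to come in near compound 1, with an estimated step of a 1.9-fold higher number from compound 2 to compound 3 (0.27 log units; within the scatter), giving an estimate of 32000 nM with a range from 12000 nM to 85000 nM.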

Compound 3, half-maximal inhibitory concentration: 28700 nM
Compound 3: middle estimate off by 1.1-fold (0.05 log units), on the high side; measured number inside the range.
By their numbers in this assay, from the lowest: compounds 2, 3 and 1 (each within the scatter of the next, the first and the last beyond it).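

In this assay both a 1.7-fold higher number from compound 2 to compound 3 (0.22 log units; within the scatter) and a 1.2-fold lower number from compound 1 to compound 3 (0.09 log units; within the scatter) stay within the scatter, so compound 3 cannot be separated from either compound 2 or compound 1, even though a 2.1-fold lower number from compound 1 to compound 2 (0.32 log units; beyond the scatter) lies beyond it. Methyl and chloro on the aromatic carbon therefore read alike here, and the pyridin-3-yl on the amide-type nitrogen in a ring stands apart only from the 4-chlorophenyl of compound 1, not from the 4-methylphenyl of compound 3. No measurement at hand gives a reason for these small differences.

Going by these compounds, all three groups at this position are six-membered aromatic rings, so the effect of a saturated ring or a longer alkyl chain there remains open. Also open, on these data alone, is what an amine or a carboxylic acid on the aromatic ring would give.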